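Working notes: from compound 3 to compound 4

This account rests on a few compounds, and the source may have more. Where it says the series, first, only, none or still open, it means among the compounds named here.

Results in a functional assay on A2780 cells (Homo sapiens) for antiproliferative activity (a higher number here means a weaker inhibitor, a lower number a stronger inhibitor), are as follows.
- compound 1 `Cn1ncc2cc(Nc3ncnn4ccc(CN5CCC(N)CC5)c34)ccc21` gives "not active" (no number reported)
- compound 2 `CC(C)Nc1ncnn2ccc(CN3CCC(N)CC3)c12` gives "not determined" (no result reported)
- compound 3 `Cc1ccccc1Nc1ncnn2ccc(CN3CCC(N)CC3)c12` gives > 5000 nM as a limit, not a number

Going by the values given here, no compound in this set has a single number yet. Compound 3 stands only at > 5000 nM as a limit in this assay and so gives a bound rather than a firm starting point.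

Compound 4 `COc1ccc(Nc2ncnn3ccc(CN4CCC(N)CC4)c23)cc1Cl` is still to be measured. It carries 3-chloro-4-methoxyphenyl in place of 2-methylphenyl on a nitrogen on an aromatic ring, with the count of the change given by 3-chloro-4-methoxyphenyl in place of 2-methylphenyl on a nitrogen on an aromatic ring for reference.

Among the compounds with values here, no measured pair differs in one place, so the series offers no step size to carry over. The expected step of a number no higher from compound 3 to compound 4 (the limit leaves the size open) is none beyond the scatter, with neither direction favoured. The estimated value for compound 4 is 5000 nM with an expected range from 1500 nM to 20000 nM around that estimate, and a further report of only a limit would be no surprise.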

Compound 4, half-maximal inhibitory concentration: > 5000 nM
Compound 4: a limit, no number; the forecaster's own chance of this, stated with the estimate: 60%; the middle value sits exactly at the limit.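

Compound 3 and compound 4 are both reported only as limits in this assay, and no step between them can be read: the limit of > 5000 nM in this assay, at which 2 of the 4 values shown sit.

The compounds shown leave open whether any group on this nitrogen gives a single number in this assay.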